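Swapping chloro for methyl on compound 3

This account rests on a few compounds, and the source may have more. Where it says the series, first, only, none or still open, it means among the compounds named here.

In a physicochemical assay for solubility, read by HPLC, measured as kinetic solubility, with a stated time of 24 h, at pH 6.5 (a lower number here means a less soluble compound, a higher number a more soluble compound), compound 3 `CCNCc1cc(Cl)cc(Nc2nc3cc(F)c(F)cc3n2Cc2ccc(C(F)(F)F)cc2)c1O` gives < 5000 nM, which is a limit of the assay and not a number. Two close relatives stand in the same place. Compound 1 `CC(C)(C)NCc1cc(Cl)cc(Nc2nc3cc(F)c(F)cc3n2Cc2ccc(C(F)(F)F)cc2)c1O` gives < 5000 nM, again a limit. Compound 2 `Cc1cc(CNC(C)(C)C)c(O)c(Nc2nc3cc(F)c(F)cc3n2Cc2ccc(C(F)(F)F)cc2)c1` gives < 5000 nM, also a limit. All the measurements so far therefore come down to one line: the limit of < 5000 nM in this assay, at which 3 of the 3 values shown sit.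

Compound 4 `CCNCc1cc(C)cc(Nc2nc3cc(F)c(F)cc3n2Cc2ccc(C(F)(F)F)cc2)c1O` differs from compound 3 in a single place, with methyl in place of chloro on an aromatic carbon, para to a hydroxy group: methyl in place of chloro on an aromatic carbon. The same swap has been measured once, and it is a step that the two limits leave unreadable from compound 1 to compound 2. That step has no size to carry over, so no step beyond the usual scatter is expected in this assay, and no direction can be named. The other measured change, ethyl in place of tert-butyl on an amine nitrogen, is a step that the two limits leave unreadable from compound 1 to compound 3, and it adds no size either.

The estimated change is a step that the limit leaves unreadable from compound 3 to compound 4. Compound 4 is expected to come in near 3000 nM, with an estimated range of 800 nM to 7000 nM. The likeliest single outcome is that this assay again reports only a limit.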

Compound 4, solubility: 16000 nM
Estimate against measurement, compound 4: 5.3-fold (0.73 log units) below; the measured number lies above the stated range.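

At the aromatic carbon para to a hydroxy group, with ethyl on the amine nitrogen, this assay shows for methyl in place of chloro an at least 3.2-fold higher number from compound 3 to compound 4 (0.50 log units; beyond the scatter), so this swap now has a direction, while the same swap from compound 1 to compound 2 could not be read. With methyl fixed on the ring, the amine change of ethyl in place of tert-butyl shows an at least 3.2-fold higher number from compound 2 to compound 4 (0.50 log units; beyond the scatter), a direction that the step from compound 1 to compound 3 could not give either. Among the four compounds, only compound 4 combines methyl with ethyl, and only compound 4 gives a number rather than a limit: the limit of < 5000 nM in this assay, at which 3 of the 4 values shown sit.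

As far as these compounds go, compounds 1, 2 and 3 all rest on a limit, so each new step gives only a minimum and its full size stays open. Also open, from the compounds shown here alone, is whether a methoxy group or a fluoro group on the same aromatic carbon, or a propyl group or a longer chain on the amine nitrogen, would move the number in the same direction.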